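The source may report more compounds than this note shows. Statements on the series, on what has been measured and on what is new or still open speak of the compounds shown alone.

For the measured compounds named here, compound 2 `CC1=C(C(=O)OCC2CC2)C(c2cccs2)NC(=O)N1` holds the higher of the two numbers measured so far in an assay on membranes from CHO cells for displacement of a labelled ligand from adenosine receptor A1 (Homo sapiens), read by scintillation counting, with a stated time of 60 min, tested at 1 uM (on this read-out lower numbers stand for less inhibition and higher numbers for more inhibition at the one concentration tested (going by the name of the read-out)), giving 23%. Compound 1 `CC1=C(C(=O)NC(C)C)C(c2cccs2)NC(=O)N1` gives 2% in this assay, and the exchange of cyclopropylmethoxy in place of isopropylamino on a carbonyl carbon brings a number 21 percentage points higher from compound 1 to compound 2 (beyond the scatter). Compound 3 `CC1=C(C(=O)OCC2CCC2)C(c2cccs2)NC(=O)N1` is yet to be measured; against compound 2 the difference is cyclobutyl in place of cyclopropyl on a saturated chain carbon bound to an oxygen next to a carbonyl group. Going by the values given here, the single measured step concerns the group attached to the carbonyl carbon and not the cyclopropyl itself, so nothing measured bears on exchanging one small ring for the next, and the series offers no guide beyond the level of compound 2. A step no larger than the scatter is therefore expected in this assay, in no fixed direction. Compound 3 is expected to give 25%, within 10% to 42%. This amounts to an expected step of a number 2 percentage points higher from compound 2 to compound 3 (within the scatter).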

Compound 3, a percentage reported as inhibition, at one concentration (the size of the read-out at that concentration, not a potency): 39%
The estimate for compound 3 lay 14 percentage points below the measured number; the range from low to high includes it.
By their numbers in this assay, from the lowest: compound 1; then compound 2; then compound 3.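

The cyclopropyl on the saturated chain carbon bound to an oxygen next to a carbonyl group is not a neutral spot: in this assay, cyclobutyl in its place gives a number 16 percentage points higher from compound 2 to compound 3 (beyond the scatter), so a three-membered and a four-membered ring of carbon only are told apart here. The step in the ring thus adds to what the ester side already showed, and exchanging the whole group on the carbonyl carbon gives a number 37 percentage points higher from compound 1 to compound 3 (beyond the scatter), the largest step among the compounds shown. No measurement at hand accounts for the difference between the two rings.

On these data alone, whether the numbers keep rising with cyclopentyl on the same carbon, or whether an open-chain group such as isopropyl or a longer chain reads like the rings, stays open. Also open, as far as these compounds go, is how the thiophene-bearing core responds when cyclobutylmethyl is carried on an amide nitrogen instead of the ester oxygen.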